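The source may report more compounds than this note shows. Statements on the series, on what has been measured and on what is new or still open speak of the compounds shown alone.

Values in a physicochemical assay for lipophilicity, using the shake flask method, in phosphate buffer, measured as octanol-water partition, with a stated time of 2 h, at pH 7.4, tested at 1 uM (a lower number here means a more polar compound, a higher number a more lipophilic compound), so far
Compound 1 `OC[C@H]1O[C@H](Oc2ccc(-n3ccc4ccccc43)cc2Cl)[C@@H](O)[C@@H](O)[C@@H]1O` gives 1.8
Compound 2 `O=[N+]([O-])c1ccc2c(ccn2-c2ccc(O[C@H]3O[C@H](CO)[C@@H](O)[C@H](O)[C@@H]3O)c(Cl)c2)c1` gives 1.8
Compound 3 `COC(=O)c1ccc2c(ccn2-c2ccc(O[C@H]3O[C@H](CO)[C@@H](O)[C@H](O)[C@@H]3O)c(Cl)c2)c1` gives 2.8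

Compound 3 stands highest of the three, with both other compounds lower by a margin beyond the scatter. The next change leads to compound 4 `CS(=O)(=O)Nc1ccc2c(ccn2-c2ccc(O[C@H]3O[C@H](CO)[C@@H](O)[C@H](O)[C@@H]3O)c(Cl)c2)c1` and is methanesulfonamido in place of methoxycarbonyl on an aromatic carbon with methanesulfonamido in place of methoxycarbonyl on an aromatic carbon. Among the measured compounds shown here, no measured compound carries methanesulfonamido, so the evidence is indirect. The steps of a number 1.00 log units higher from compound 1 to compound 3 (beyond the scatter) and a number 1.00 log units higher from compound 2 to compound 3 (beyond the scatter) are the only ones beyond the scatter so far and both lead to the methoxycarbonyl compound, whereas nitro shows no change at the digits printed from compound 1 to compound 2 (within the scatter) in this small set. Removing methoxycarbonyl is therefore expected to give up a step of similar size or slightly larger, with compound 4 expected a little under compound 1 at 1.8 in this comparison. The expected change is a number 1.30 log units lower from compound 3 to compound 4 (beyond the scatter) and would lie beyond the scatter. Compound 4 is estimated at 1.5 with an expected range of 1 to 2 for now.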

Compound 4, distribution coefficient: 1.8
Compound 4: the middle estimate sits 0.30 log units below what was measured; low and high end bracket the measured number.
By their numbers in this assay, from the lowest: compounds 1, 2 and 4 (each within the scatter of the next); then compound 3.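

In this assay, methanesulfonamido gives a number 1.00 log units lower from compound 3 to compound 4 (beyond the scatter), so methoxycarbonyl is no longer set apart only by comparison with hydrogen and nitro. Among the compounds shown here, at this place, para to a fused ring, methanesulfonamido shows no change at the digits printed from compound 1 to compound 4 (within the scatter) and no change at the digits printed from compound 2 to compound 4 (within the scatter), leaving hydrogen, nitro and methanesulfonamido together, with methoxycarbonyl the only group apart, even though methanesulfonamido is the larger of the two groups exchanged and adds a hydrogen-bond donor. No measurement here accounts for the difference between methoxycarbonyl and the other groups.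

As far as these compounds go, whether a carboxylic acid, a primary amine or an ethyl ester at this place would fall with methoxycarbonyl or with the other three remains open. So does whether the same order of groups holds at another carbon of the same ring.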